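The source may hold more compounds than are shown below. What is called first, only, known or untested is meant among the compounds shown, and "the series" means these compounds.

Three analogues share one core, a diethylamino-substituted benzofuranyl ketone carrying a piperazine whose ring nitrogen bears a varying group. Compound 1 `CCN(CC)c1ccc2cc(C(=O)c3ccc(N4CCN(C(=O)COc5ccc(Cl)cc5Cl)CC4)cc3)oc2c1` gives 6170 nM in a functional assay on SGC-7901 cells (Homo sapiens) for cytotoxicity, read by MTT assay, with a stated time of 48 h; a higher number here means a weaker inhibitor, a lower number a stronger inhibitor. Compound 2 `CCN(CC)c1ccc2cc(C(=O)c3ccc(N4CCN(S(=O)(=O)c5ccc([N+](=O)[O-])cc5)CC4)cc3)oc2c1` gives 1860 nM in this assay, a change of a 3.3-fold lower number from compound 1 to compound 2 (0.52 log units; beyond the scatter). Compound 3 `CCN(CC)c1ccc2cc(C(=O)c3ccc(N4CCN(S(=O)(=O)c5ccc(C(F)(F)F)cc5)CC4)cc3)oc2c1` gives 170 nM in this assay and stands lowest of the three, a change of an 11-fold lower number from compound 2 to compound 3 (1.04 log units; beyond the scatter).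

Compound 4 `CCN(CC)c1ccc2cc(C(=O)c3ccc(N4CCN(S(=O)(=O)c5ccc(Br)c(F)c5)CC4)cc3)oc2c1` differs from compound 3 at the sulfonyl sulfur: 4-bromo-3-fluorophenyl in place of 4-(trifluoromethyl)phenyl on a sulfonyl sulfur. For the measured compounds named here, the step that bears on this is the one from compound 2 to compound 3, where exchanging the group on that same phenyl ring gave a change of an 11-fold lower number from compound 2 to compound 3 (1.04 log units; beyond the scatter); the step from compound 1 to compound 2 concerns a different part and speaks only to the sulfonyl series as a whole. Going by the values given here, since 4-bromo-3-fluorophenyl is a new group, no measured step matches it directly. The author expects a modest step in this assay, most likely a somewhat higher number, a 2.1-fold higher number from compound 3 to compound 4 (0.31 log units; beyond the scatter), given the distance of compound 3 from compound 2 at an 11-fold lower number from compound 2 to compound 3 (1.04 log units; beyond the scatter). Compound 4 is estimated at 350 nM, within 100 nM to 1500 nM.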

Compound 4, half-maximal inhibitory concentration: > 40000 nM
Compound 4 was reported as a limit; the forecaster's own chance of this, stated with the estimate: 3%; middle value at least 110-fold (2.05 log units) from the limit.
By their numbers in this assay, from the lowest: compound 3; then compound 2; then compound 1. At a limit, above all of these: compound 4.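

In this assay compound 4 is reported only as a limit, not as a number: the limit of > 40000 nM in this assay, at which 1 of the 4 values shown sits. For the compounds shown here, on the sulfonyl sulfur, 4-bromo-3-fluorophenyl in place of 4-(trifluoromethyl)phenyl gives an at least 230-fold higher number from compound 3 to compound 4 (2.37 log units; beyond the scatter), so the group at this position can move the result far more sharply upward than the earlier compounds showed. The sulfonyl link alone therefore does not secure a low number, as the earlier sulfonyl compounds suggested: the step from the nitro analogue is an at least 21-fold higher number from compound 2 to compound 4 (1.33 log units; beyond the scatter), and even the carbonyl-linked compound gives an at least 6.4-fold higher number from compound 1 to compound 4 (0.81 log units; beyond the scatter).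

The compounds shown leave open whether the bromine or the fluorine drives this loss, a question that a 4-bromophenyl or a 3-fluorophenyl group on the sulfonyl sulfur would address. They also leave open how an amine or a carboxylic acid on that phenyl ring would read in this assay.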